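A few compounds are considered here, and "the series" means these few. Any claim that something is new, unique, unknown or untested is made for them only; others in the source may bear on it.

Compound 1 `CC1(C)CNC(=O)c2sc(Nc3ccc(I)cc3F)c(C(=O)NCCCO)c2C1`: 6210 nM
Compound 2 `CC1(C)CNC(=O)c2sc(Nc3ccc(I)cc3Cl)c(C(=O)NOC[C@H](O)CO)c2C1`: 896 nM

Among the compounds with values here, in a functional assay on HT-29 cells (Homo sapiens) for antiproliferative activity (on this read-out higher numbers stand for weaker inhibition and lower numbers for stronger inhibition), compound 2 stands at the lowest of the two numbers, while compound 1 gives the higher value; the two differ in more than one place, so no single step links them. Compound 3 `CC(C)(N)CNC(=O)c1c(Nc2ccc(I)cc2Cl)sc2c1CC(C)(C)CNC2=O` differs from compound 2 in one place: 2-amino-2-methylpropyl in place of 2,3-dihydroxypropoxy on an amide-type nitrogen. Within the data shown here, no measured pair shows this change, so its size is uncertain; a shift within or slightly beyond the scatter toward weaker inhibition is expected. Compound 3 is expected to give 1400 nM, with a range from 400 nM to 5000 nM. This estimate corresponds to an expected step of a 1.6-fold higher number from compound 2 to compound 3 (0.19 log units; within the scatter).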

Compound 3, half-maximal inhibitory concentration: 113 nM
Compound 3: the middle estimate sits 12-fold (1.09 log units) above what was measured; the measured number lies below the stated range.
By their numbers in this assay, from the lowest: compound 3; then compound 2; then compound 1.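

In this assay, putting 2-amino-2-methylpropyl in place of 2,3-dihydroxypropoxy on the amide-type nitrogen gives a 7.9-fold lower number from compound 2 to compound 3 (0.90 log units; beyond the scatter), a step beyond the scatter. This is the first single-place comparison among these compounds, and it shows that the group on this nitrogen can affect inhibition substantially and that the 2,3-dihydroxypropoxy group is not required for activity here. No available evidence explains the gain. The compounds shown leave open whether the amine itself accounts for the step, which a 2-hydroxy-2-methylpropyl or plain 2-methylpropyl group in its place would help to separate.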